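Extending the butyl ether chain: compound 2 to compound 3

The compounds below may be only part of what the source reports. "The series", "measured", "known", "first", "only" and "open" are said of these compounds alone.

Compound 1 `CN(C)CCNc1ccnc2cc(OCc3ccc(F)cc3)ccc12`: 810 nM
Compound 2 `CCCCOc1ccc2c(Cl)ccnc2c1`: 3780 nM

In a functional assay on DLD-1 cells (Homo sapiens) for cytotoxicity, read by MTT assay, with a stated time of 48 h (on this read-out higher numbers stand for weaker inhibition and lower numbers for stronger inhibition), compound 2 gives the higher of the two numbers on record, with compound 1 the nearest neighbour at a clearly lower value; that gap lies beyond the scatter of the measurement. Compound 3 `CCCCCCOc1ccc2c(Cl)ccnc2c1` has not yet been measured. It differs from compound 2 by ethyl in place of hydrogen on a saturated chain carbon, four bonds along the chain from an oxygen on an aromatic ring. Among the measured compounds shown here, no measured pair in this set isolates such a change, so there is no step to lean on. The expectation in this assay is a small step, possibly a modest lowering of the number, not clearly beyond the scatter. The step expected is a 1.5-fold lower number from compound 2 to compound 3 (0.16 log units; within the scatter). Compound 3 is accordingly estimated at 2600 nM, within a range from 900 nM to 8000 nM.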

Compound 3, half-maximal inhibitory concentration: 2660 nM
For compound 3 the middle estimate is 1.0-fold (0.01 log units) below the measured one; the range from low to high includes it.
By their numbers in this assay, from the lowest: compound 1; then compounds 3 and 2 (each within the scatter of the next).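

Working note: in this assay, the first single-place step in the series, ethyl in place of hydrogen on a saturated chain carbon, four bonds along the chain from an oxygen on an aromatic ring, reads as a 1.4-fold lower number from compound 2 to compound 3 (0.15 log units; within the scatter) and stays within the scatter. This chain position therefore accepts the ethyl extension with no change that can be told from noise, which compound 1, differing from compound 2 in more than one place, could not show. No supporting measurement bears on this result.

One step on one chain cannot show whether a longer chain, such as octyl, would move the number beyond the scatter. Equally open, going by these compounds, is what a chain ending in an amine or a carboxylic acid would do at this position.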